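Bromo in place of hydrogen on the phenyl of compound 2

A few compounds are considered here, and "the series" means these few. Any claim that something is new, unique, unknown or untested is made for them only; others in the source may bear on it.

Measured so far:
Compound 1, `COc1ccc(-c2cn(/N=C/c3cc4ccccc4nc3Cl)c(N)n2)cc1`, 31800 nM
Compound 2, `Cc1ccc2nc(Cl)c(/C=N/n3cc(-c4ccccc4)nc3N)cc2c1`, 7120 nM

Both compounds were tested in a functional assay on HCT-116 cells (Homo sapiens) for cytotoxicity, read by MTT assay, with a stated time of 48 h; a lower number here means a stronger inhibitor, a higher number a weaker inhibitor. Compound 2 gives 7120 nM and holds the lowest number of the two; its nearest neighbour, compound 1, gives 31800 nM, a difference that lies beyond the usual scatter. The two structures differ in more than one place, so their values are only compared, not explained.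

Compound 3, `Cc1ccc2nc(Cl)c(/C=N/n3cc(-c4ccc(Br)cc4)nc3N)cc2c1`, has not yet been measured in this assay. It differs from compound 2 in one respect: bromo in place of hydrogen on an aromatic carbon, or, cut one bond further out, phenyl to 4-bromophenyl. Within the data shown here, no measured pair shows this change on its own, so there is nothing to anchor the size of the step. In this assay the step is expected to be small, at most modest in the direction of a lower number, and quite possibly within the scatter, a 1.4-fold lower number from compound 2 to compound 3 (0.15 log units; within the scatter). Compound 3 is therefore estimated at 5000 nM, within a range of 1500 nM to 17000 nM.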

Compound 3, half-maximal inhibitory concentration: 49900 nM
Compound 3: middle estimate off by 10-fold (1.00 log units), on the low side, and the stated range ends below it.
By their numbers in this assay, from the lowest: compound 2; then compounds 1 and 3 (each within the scatter of the next).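

Bromo in place of hydrogen on an aromatic carbon, para to a large group, gives a 7.0-fold higher number from compound 2 to compound 3 (0.85 log units; beyond the scatter) in this assay and is the only single change shown on this phenyl. This step lies beyond the scatter, so this position is not indifferent to substitution, and here the 4-bromophenyl gives a weaker inhibitor than the unsubstituted phenyl. Nothing measured among the data shown bears on why the number rises.

Going by these compounds, whether the rise is particular to bromo or would also follow from fluoro, an amine or a carboxylic acid on the same carbon remains open. Also open, on these data alone, is whether bromo on another carbon of this phenyl would move the number in the same direction or by a similar amount.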